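This account rests on a few compounds, and the source may have more. Where it says the series, first, only, none or still open, it means among the compounds named here.

Compound 2 `CCCCCCCCCCCCCCCCCCNC(=O)[C@@H](NC(=O)c1cc2ccccc2n1C)[C@@H](C)O` stands highest of the two numbers in a functional assay on SW-620 cells (Homo sapiens) for cytotoxicity, read by MTT assay, with a stated time of 48 h (on this read-out higher numbers stand for weaker inhibition and lower numbers for stronger inhibition), where compound 2 gives 124000 nM. Its nearest neighbour is compound 1 `CCCCCCCCCCCCCCCCCCNC(=O)[C@@H](NC(=O)c1cc2ccccc2[nH]1)[C@@H](C)O`, which gives 23600 nM. For the measured compounds named here, the only measured step, a 5.3-fold higher number from compound 1 to compound 2 (0.72 log units; beyond the scatter), came from methyl in place of hydrogen on an aromatic nitrogen. Compound 3 `CCCCCCCCCCCCCCCCCCNC(=O)[C@@H](NS(=O)(=O)c1ccc(C)cc1)[C@@H](C)O` differs from compound 2 by (4-methylphenyl)sulfonyl in place of (1-methyl-1H-indol-2-yl)carbonyl on an amine nitrogen. Going by the values given here, no measured step covers a replacement of this kind, so the direction of change is uncertain. A modest step is expected, a 1.2-fold lower number from compound 2 to compound 3 (0.09 log units; within the scatter). Compound 3 is therefore expected to give about 100000 nM, somewhere between 30000 nM and 400000 nM.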

Compound 3, half-maximal inhibitory concentration: 32500 nM
The estimate for compound 3 lay 3.1-fold (0.49 log units) above the measured number; low and high end bracket the measured number.
By their numbers in this assay, from the lowest: compounds 1 and 3 (each within the scatter of the next); then compound 2.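

In this assay (4-methylphenyl)sulfonyl in place of (1-methyl-1H-indol-2-yl)carbonyl on this amine nitrogen gives a 3.8-fold lower number from compound 2 to compound 3 (0.58 log units; beyond the scatter) and so shows that the group here can be exchanged entirely without a loss. Set against the indole group without the methyl, the same kind of swap gives a 1.4-fold higher number from compound 1 to compound 3 (0.14 log units; within the scatter) and leaves compound 2 alone as the weakest of the three. Nothing measured here explains either step. As far as these compounds go, whether a benzoyl or a methanesulfonyl group on this nitrogen would hold the same level stays open, as does the effect of a shorter chain.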